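Swapping methyl for cyano on compound 1

This account rests on a few compounds, and the source may have more. Where it says the series, first, only, none or still open, it means among the compounds named here.

Among the measured compounds shown here, in a functional assay on HepG2 cells (Homo sapiens) for inhibition, read by MTT assay, with a stated time of 24 h (on this read-out lower numbers stand for stronger inhibition and higher numbers for weaker inhibition), compound 1 `Cc1ccc(C(=O)NCC(=O)N/N=C/c2ccccc2OCc2ccccc2Cl)cc1` gives 13400 nM, the only actual number so far. Compound 2 `COc1ccc(COc2ccccc2/C=N/NC(=O)CNC(=O)c2ccc(C)cc2)cc1` gives > 50000 nM, which is a limit of the assay. For the measured compounds named here, the one measured step is an at least 3.7-fold higher number from compound 1 to compound 2 (0.57 log units; beyond the scatter), with 4-methoxyphenyl in place of 2-chlorophenyl. Compound 3 `N#Cc1ccc(C(=O)NCC(=O)N/N=C/c2ccccc2OCc2ccccc2Cl)cc1` changes a different place: cyano in place of methyl on an aromatic carbon. The measured step from compound 1 to compound 2 therefore offers no direct guide, so no shift beyond the scatter is expected in this assay. The expected result is a 1.0-fold higher number from compound 1 to compound 3 (0.02 log units; within the scatter). For compound 3 the estimated value is 14000 nM, with an expected range from 5000 nM to 40000 nM.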

Compound 3, half-maximal inhibitory concentration: > 50000 nM
Compound 3: a limit, no number; the forecaster's own chance of this, stated with the estimate: 15%; middle value at least 3.5-fold (0.55 log units) from the limit.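

In this assay, cyano in place of methyl gives an at least 3.7-fold higher number from compound 1 to compound 3 (0.57 log units; beyond the scatter), so this position, para to a large group, also affects the read-out, as the 4-methoxyphenyl change in compound 2 did in a different place. Compound 3 reads only as a limit of the assay, so the full size of this step stays unknown: the limit of > 50000 nM in this assay, at which 2 of the 3 values shown sit.

With only methyl and cyano shown here, it remains open whether the weaker result is specific to cyano or follows any replacement of methyl. An amine or a plain hydrogen at this position would help separate these two readings.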